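Series notes: tolerated concentrations and the step to compound 4

This account rests on a few compounds, and the source may have more. Where it says the series, first, only, none or still open, it means among the compounds named here.

Compound 1 `COc1nc2ccccc2cc1/C=C/c1noc(-c2ccc(C)cc2)n1`: in an ADME assay on HepG2 cells (Homo sapiens) for cytotoxicity, read by sulforhodamine B assay, with a stated time of 48 h (a higher number here means that more compound is tolerated, a lower number that less compound is tolerated), compound 1 gives > 230000 nM, which is a limit of the assay and not a number.
Compound 2 `COc1nc2ccccc2cc1/C=C/c1noc(-c2ccccc2C)n1`: in this assay compound 2 gives > 230000 nM, again a limit.
Compound 3 `COc1nc2ccccc2cc1/C=C/c1noc(-c2cccc(Cl)c2)n1`: in this assay compound 3 gives > 220000 nM, also a limit.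

Compound 3 therefore stands at a limit, as do the two other values shown: one sits at the limit of > 220000 nM in this assay, at which 1 of the 3 values shown sits, and two at the limit of > 230000 nM in this assay, at which 2 of the 3 values shown sit. Within the data shown here, none of the measured steps can be read: a step that the two limits leave unreadable from compound 1 to compound 2, a step that the two limits leave unreadable from compound 1 to compound 3 and a step that the two limits leave unreadable from compound 2 to compound 3 are all hidden behind the limits, so no size or direction is known for any change of the aryl group on the shared core.

The next compound, compound 4 `COc1nc2ccccc2cc1/C=C/c1noc(COc2ccccc2)n1`, differs from compound 3 by phenoxymethyl in place of 3-chlorophenyl on an aromatic carbon. Among the measured compounds shown here, the measured steps bear on it only in that every aryl variation so far has left the value at a limit in this assay, giving no readable movement. Compound 4 is therefore expected to show no step beyond the scatter, a number no higher from compound 3 to compound 4 (the limit leaves the size open), with a fair chance that only a limit is reported again. The estimate for compound 4 in this assay is 220000 nM, within a range of 90000 nM to 300000 nM.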

Compound 4, half-maximal cytotoxic concentration: > 220000 nM
Compound 4 ended at the assay's limit; the forecaster's own chance of this, stated with the estimate: 65%; the middle value lies on the limit itself.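

In this assay compound 4 gives > 220000 nM, a limit of the assay and not a number. The steps joining compound 1, compound 2 and compound 3 to compound 4 therefore cannot be read. The compounds shown leave open whether phenoxymethyl or any of the aryl groups on the shared core changes the tolerated concentration at all.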